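The compounds below may be only part of what the source reports. "The series", "measured", "known", "first", "only" and "open" are said of these compounds alone.

Series notes. Compound 1 `CC1CCN(C2CCN(S(=O)(=O)c3cccnc3)CC2)CC1` and compound 2 `CC1CCN(C2CCN(S(=O)(=O)c3cccnc3F)CC2)CC1` share a core and differ by hydrogen in place of fluoro on an aromatic carbon. In a functional assay on DLD-1 cells (Homo sapiens) for antiproliferative activity, read by CellTiter-Glo, with a stated time of 72 h (a higher number here means a weaker inhibitor, a lower number a stronger inhibitor), compound 1 gives 2400 nM. Compound 2 in this assay reaches only a limit, > 5000 nM. The step of an at least 2.0-fold lower number from compound 2 to compound 1 (0.31 log units; beyond the scatter) is therefore bounded on one side because of the limit of > 5000 nM in this assay, at which 1 of the 3 values shown sits. Compound 3 `Cc1cc(C)c(S(=O)(=O)N2CCC(N3CCC(Cc4ccccc4F)CC3)CC2)c(C)c1` carries a different core; how the core of compound 3 differs from that of compound 2 is not broken down here. In this assay compound 3 gives 74 nM. Compound 4 `Cc1cc(C)c(S(=O)(=O)N2CCC(N3CCC(Cc4ccccc4)CC3)CC2)c(C)c1` is not yet measured; it differs from compound 3 by hydrogen in place of fluoro on an aromatic carbon, the same kind of change as from compound 2 to compound 1, but here on a six-membered aromatic ring of carbon only rather than one with one nitrogen, next to the ring nitrogen. For compound 4 the expected step is a 1.2-fold higher number from compound 3 to compound 4 (0.09 log units; within the scatter), resting on the measured change from compound 2 to compound 1 while allowing that the surroundings differ. Compound 4 is estimated at 90 nM, between 40 nM and 200 nM.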

Compound 4, half-maximal inhibitory concentration: 3.5 nM
Estimate against measurement, compound 4: 26-fold (1.41 log units) above; measured number below the stated range.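

In this assay, hydrogen in place of fluoro gives a 21-fold lower number from compound 3 to compound 4 (1.33 log units; beyond the scatter), so the direction of the change on the core of compound 1 also appears on the core of compound 4. Whether the size of the change carries from one core to the other cannot be read: the same change on two cores in this assay, an at least 2.0-fold lower number (0.31 log units; beyond the scatter) from compound 2 to compound 1 and a 21-fold lower number (1.33 log units; beyond the scatter) from compound 3 to compound 4; the limit leaves it open whether they differ The value of compound 2, > 5000 nM, is a limit and not a number, and two pairs make no general rule for the series.

Still open, as far as these compounds go, is how chloro, methyl or methoxy in place of the fluoro of the 2-fluorobenzyl group would read in this assay. Also open, from the compounds shown here alone, is how a phenethyl group in place of benzyl would compare.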